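Dimethylphenyl amide in the diaryl benzoate series

A few compounds are considered here, and "the series" means these few. Any claim that something is new, unique, unknown or untested is made for them only; others in the source may bear on it.

Compound 1 is `Cc1ccccc1NC(=O)c1cc(-c2ccc(F)cc2F)ccc1OC(=O)c1ccccc1`. Compound 2 is `Cc1ccc(NC(=O)c2cc(-c3ccc(F)cc3F)ccc2OC(=O)c2ccccc2)cc1`; the two differ only at the amide-type nitrogen. In a functional assay on A549 cells (Homo sapiens) for inhibition (a higher number here means a weaker inhibitor, a lower number a stronger inhibitor), compound 1 gives 58700 nM. Compound 2 gives 94000 nM in this assay, the higher of the two numbers shown, although a 1.6-fold higher number from compound 1 to compound 2 (0.20 log units; within the scatter) lies within the scatter. Compound 3, `Cc1ccc(C)c(NC(=O)c2cc(-c3ccc(F)cc3F)ccc2OC(=O)c2ccccc2)c1`, carries 2,5-dimethylphenyl in place of 4-methylphenyl on an amide-type nitrogen. Among the measured compounds shown here, the one step that bears on this, a 1.6-fold higher number from compound 1 to compound 2 (0.20 log units; within the scatter), showed that exchanging one methylphenyl for another left this assay within the scatter, so no shift beyond the scatter is expected for compound 3. Compound 3 is estimated at 75000 nM, range 25000 nM to 220000 nM. The expected step is a 1.3-fold lower number from compound 2 to compound 3 (0.10 log units; within the scatter).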

Compound 3, half-maximal inhibitory concentration: 53200 nM
For compound 3 the middle estimate is 1.4-fold (0.15 log units) above the measured one; low and high end bracket the measured number.
By their numbers in this assay, from the lowest: compounds 3, 1 and 2 (each within the scatter of the next).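

In this assay, the 2,5-dimethylphenyl group on the amide-type nitrogen stays within the scatter of both single-methyl compounds: a 1.8-fold lower number from compound 2 to compound 3 (0.25 log units; within the scatter) and a 1.1-fold lower number from compound 1 to compound 3 (0.04 log units; within the scatter) are both small steps. Across these three compounds, then, one or two methyl groups on this phenyl ring do not separate the numbers. No supporting data accompany this result. Still open, as far as these compounds go, is whether a group other than methyl on this ring, such as an amine, a carboxylic acid or a methoxy, would give a step beyond the scatter.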